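The compounds below may be only part of what the source reports. "The series", "measured", "known", "first", "only" and "open" are said of these compounds alone.

Measured in a functional assay on SW-620 cells (Homo sapiens) for inhibition, read by MTT assay, with a stated time of 72 h; on this read-out higher numbers stand for weaker inhibition and lower numbers for stronger inhibition:
compound 1 `COc1cc(NC(C)CCCNC(=O)Nc2cccc(F)c2)c2ncccc2c1`: 27000 nM
compound 2 `COc1cc(NC(C)CCCNC(=O)NNC(=O)Nc2cccc(F)c2)c2ncccc2c1`: 9500 nM

Compound 2 holds the lower of the two numbers, at 9500 nM. Next in line is compound 3 `COc1cc(NC(C)CCCNC(=O)Nc2ccc(O)cc2)c2ncccc2c1`, which carries 4-hydroxyphenyl in place of ((3-fluorophenyl)carbamoyl)amino on an amide-type nitrogen. For the measured compounds named here, one measured step bears on this change: a 2.8-fold lower number from compound 1 to compound 2 (0.45 log units; beyond the scatter). That step is modest, and it put ((3-fluorophenyl)carbamoyl)amino in place of 3-fluorophenyl. Compound 3 lacks that group again, so a step of similar modest size towards a higher number is expected in this assay. Going by the values given here, no measured step covers 4-hydroxyphenyl, so the range is kept wide. The expected step is a 1.9-fold higher number from compound 2 to compound 3 (0.28 log units; within the scatter). For compound 3 the estimated value is 18000 nM, with a range of 6000 nM to 45000 nM.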

Compound 3, half-maximal inhibitory concentration: 30000 nM
The estimate for compound 3 lay 1.7-fold (0.22 log units) below the measured number; the measured number falls inside the stated range.
By their numbers in this assay, from the lowest: compound 2; then compounds 1 and 3 (each within the scatter of the next).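

In this assay, 4-hydroxyphenyl in place of ((3-fluorophenyl)carbamoyl)amino on the amide-type nitrogen reverses the earlier gain (a 3.2-fold higher number from compound 2 to compound 3 (0.50 log units; beyond the scatter)). Exchanging 3-fluorophenyl for 4-hydroxyphenyl on that nitrogen gives no separation (a 1.1-fold higher number from compound 1 to compound 3 (0.05 log units; within the scatter)), so among these three compounds only compound 2, with ((3-fluorophenyl)carbamoyl)amino, stands apart from the other two. No measured evidence accounts for either step.

As far as these compounds go, whether the 4-hydroxyphenyl ring would keep the number of compound 2 when carried on the ((3-fluorophenyl)carbamoyl)amino extension, with its 3-fluorophenyl exchanged, remains open. Also open, from the compounds shown here alone, is what an amine or a carboxylic acid on the phenyl ring, or a longer chain on the amide-type nitrogen, would do in this assay series.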